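The source may hold more compounds than are shown below. What is called first, only, known or untested is meant among the compounds shown, and "the series" means these compounds.

The measured compounds:
Compound 1, `COc1cc2c(Oc3ccc(NC(=O)c4nnn(-c5ccccc5C)c4C)cc3F)ccnc2cc1OCCCN1CCCC1`, gives 1600 nM in a functional assay on U-87MG ATCC cells (Homo sapiens) for cytotoxicity, read by MTT assay, with a stated time of 72 h; on this read-out higher numbers stand for weaker inhibition and lower numbers for stronger inhibition.
Compound 2, `COc1cc2c(Oc3ccc(NC(=O)c4nnn(-c5ccccc5)c4C)cc3F)ccnc2cc1OCCCN1CCCC1`, gives 1000 nM in this assay.
Compound 3, `COc1cc2c(Oc3ccc(NC(=O)c4nnn(-c5ccccc5C)c4C)cc3F)ccnc2cc1OCCCN1CCCCC1`, gives 2370 nM in this assay.

Compound 1 and compound 2 share one core and differ in a single place: hydrogen in place of methyl on an aromatic carbon. This change gives a 1.6-fold lower number from compound 1 to compound 2 (0.20 log units; within the scatter). Compound 3 carries a different core from compound 1; the two differ by piperidin-1-yl in place of pyrrolidin-1-yl on a saturated chain carbon, three bonds along the chain from an oxygen on an aromatic ring, and that change gives a 1.5-fold higher number from compound 1 to compound 3 (0.17 log units; within the scatter). The values of compound 3 and compound 1 lie within the scatter of each other, whereas the values of compound 3 and compound 2 are separated beyond it.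

Compound 4, `COc1cc2c(Oc3ccc(NC(=O)c4nnn(-c5ccccc5)c4C)cc3F)ccnc2cc1OCCCN1CCCCC1`, is not yet measured in this assay. It stands to compound 3 exactly as compound 2 stands to compound 1: the difference is hydrogen in place of methyl on an aromatic carbon. The place of the change is the same word for word in both pairs, so this is the same change, made here on the core of compound 3 rather than on the core of compound 1. Going by the values given here, with only one earlier example of it, the expectation rests on that example alone. The expected step from compound 3 to compound 4 in this assay is a 1.6-fold lower number from compound 3 to compound 4 (0.20 log units; within the scatter), and it rests on the change having given a 1.6-fold lower number from compound 1 to compound 2 (0.20 log units; within the scatter). Compound 4 is accordingly expected at 1500 nM. The range estimated for compound 4 runs from 700 nM to 3500 nM.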

Compound 4, half-maximal inhibitory concentration: 1130 nM
Estimate against measurement, compound 4: 1.3-fold (0.12 log units) above, within the range that was stated.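

In this assay, going from 2-methylphenyl to phenyl on the core of compound 3 gave a 2.1-fold lower number from compound 3 to compound 4 (0.32 log units; beyond the scatter), and beside its earlier example this step shows that the change carried over from one core to the other with no difference beyond the scatter: the same change on two cores in this assay, a 1.6-fold lower number (0.20 log units; within the scatter) from compound 1 to compound 2 and a 2.1-fold lower number (0.32 log units; beyond the scatter) from compound 3 to compound 4, 1.3-fold (0.12 log units) apart, within the scatter of two such steps. Piperidin-1-yl in place of pyrrolidin-1-yl, read on the two phenyl compounds, gave a 1.1-fold higher number from compound 2 to compound 4 (0.05 log units; within the scatter), and this change also carried over: the same change on two cores in this assay, a 1.5-fold higher number (0.17 log units; within the scatter) from compound 1 to compound 3 and a 1.1-fold higher number (0.05 log units; within the scatter) from compound 2 to compound 4, 1.3-fold (0.12 log units) apart, within the scatter of two such steps. These results show that each change behaved alike on the two cores shown, but each rests on only two pairs, and the methyl removal lies within the scatter on one core and beyond it on the other, so they do not establish a firm gain from that removal or show that either change would carry over to any further core.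

The compounds shown leave open what a chlorine atom or a methoxy group would do in place of the methyl on the aromatic ring. They also leave open how morpholin-4-yl, in place of pyrrolidin-1-yl or piperidin-1-yl, or a longer chain carrying these rings would read in the same cells.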